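This account rests on a few compounds, and the source may have more. Where it says the series, first, only, none or still open, it means among the compounds named here.

Measured so far:
compound 1 `CCCN(C)C(=O)c1cc2c(Cc3ccccc3)n[nH]c2cc1O` — > 10000 nM
compound 2 `CN(Cc1ccccc1Cl)C(=O)c1cc2c(Cc3ccccc3)n[nH]c2cc1O` — 1100 nM
compound 3 `CN(Cc1cccc(Cl)c1)C(=O)c1cc2c(Cc3ccccc3)n[nH]c2cc1O` — 5300 nM

In a functional assay on A2780 cells (Homo sapiens) for antiproliferative activity, read by resazurin assay, with a stated time of 72 h (a higher number here means a weaker inhibitor, a lower number a stronger inhibitor), compound 1 gives no number but a limit, (the limit of > 10000 nM in this assay, at which 1 of the 3 values shown sits). Compound 4 `COc1cccc(CN(C)C(=O)c2cc3c(Cc4ccccc4)n[nH]c3cc2O)c1OC` differs from it by 2,3-dimethoxyphenyl in place of ethyl on a saturated chain carbon bound to an amide-type nitrogen. Within the data shown here, two measured steps bear on this change, both at the same place: an at least 9.0-fold lower number from compound 1 to compound 2 (0.95 log units; beyond the scatter) and an at least 1.8-fold lower number from compound 1 to compound 3 (0.27 log units; that floor lies within the scatter). The two chlorophenyl compounds also differ from each other, a 4.8-fold higher number from compound 2 to compound 3 (0.68 log units; beyond the scatter). No dimethoxyphenyl has been measured, so the size is uncertain, but a lower number than the limit of compound 1 is expected, somewhere between the two chlorophenyl steps. The expected step is an at least 4.0-fold lower number from compound 1 to compound 4 (0.60 log units; beyond the scatter). Compound 4 is therefore estimated at 2500 nM, with a range from 700 nM to 9000 nM.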

Compound 4, half-maximal inhibitory concentration: 4800 nM
Compound 4: middle estimate off by 1.9-fold (0.28 log units), on the low side, and the stated range covers the measured number.
By their numbers in this assay, from the lowest: compound 2; then compounds 4 and 3 (each within the scatter of the next). At a limit, above all of these: compound 1.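

Compound 1 is held only at a limit: the limit of > 10000 nM in this assay, at which 1 of the 4 values shown sits. Against it, 2,3-dimethoxyphenyl on the saturated chain carbon bound to an amide-type nitrogen still gives an at least 2.0-fold lower number from compound 1 to compound 4 (0.31 log units; beyond the scatter), so a step beyond the scatter is not confined to 2-chlorophenyl. The new group does not match 2-chlorophenyl, with a 4.4-fold higher number from compound 2 to compound 4 (0.64 log units; beyond the scatter), and it stands level with 3-chlorophenyl, with a 1.1-fold lower number from compound 3 to compound 4 (0.04 log units; within the scatter), which leaves compound 2 apart from the other two.

Open, on these data alone, is how unsubstituted phenyl, 2-methoxyphenyl or pyridyl at this place would compare with compound 2. Also open, as far as these compounds go, is whether any other group on the amide-type nitrogen in place of methyl would keep these numbers.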